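The source may hold more compounds than are shown below. What is called first, only, known or untested is meant among the compounds shown, and "the series" means these compounds.

Measured in a functional assay on cells (Melanoma cell, Homo sapiens) for cytotoxicity, with a stated time of 48 h; a higher number here means a weaker inhibitor of growth, a lower number a stronger inhibitor of growth:

compound 1 `COc1c(/C=C2/C(=O)Nc3ccccc32)c2ccccc2n1-c1ccccc1` — 3980 nM
compound 2 `O=C1Nc2ccccc2/C1=C\c1c(Cl)n(CCCc2ccccc2)c2ccccc12` — 67600 nM
compound 3 `COc1c(/C=C2/C(=O)Nc3ccc(Cl)cc32)c2ccccc2n1-c1ccccc1` — 18200 nM

Compound 1 and compound 3 differ by one change, (chloro in place of hydrogen on an aromatic carbon), and that change gave a 4.6-fold higher number from compound 1 to compound 3 (0.66 log units; beyond the scatter). Compound 2 rests on a different core; how its core differs from that of compound 1 is not broken down here. In this assay compound 2 gives the highest of the three numbers, and its value stands well apart from that of compound 1.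

Compound 4 `O=C1Nc2ccc(Cl)cc2/C1=C\c1c(Cl)n(CCCc2ccccc2)c2ccccc12` is not yet measured. It relates to compound 2 as compound 3 relates to compound 1: the change is chloro in place of hydrogen on an aromatic carbon, and the place of the entering chloro is described in the same words for both pairs, so the change is the same one. For the measured compounds named here, only the one precedent exists, and it was made on the other core. The expected step in this assay is a 3.7-fold higher number from compound 2 to compound 4 (0.57 log units; beyond the scatter), set beside the earlier step, because the precedent a 4.6-fold higher number from compound 1 to compound 3 (0.66 log units; beyond the scatter) went the same way and nothing in the shown data argues for a different direction on the core of compound 2. The number expected for compound 4 is therefore 250000 nM, with a plausible range from 70000 nM to 900000 nM; given where compound 2 already stands, a reported limit rather than a number is a real possibility.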

Compound 4, concentration for total growth inhibition: 5750 nM
Estimate against measurement, compound 4: 43-fold (1.64 log units) above; the whole stated range lies above it.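

In this assay, chloro in place of hydrogen on an aromatic carbon gave a 12-fold lower number from compound 2 to compound 4 (1.07 log units; beyond the scatter), so the change does not carry over between the two cores in either direction or size: the same change on two cores in this assay, a 4.6-fold higher number (0.66 log units; beyond the scatter) from compound 1 to compound 3 and a 12-fold lower number (1.07 log units; beyond the scatter) from compound 2 to compound 4, 54-fold (1.73 log units) apart, beyond the scatter of two such steps

The step seen on the core of compound 1 therefore gave no reliable guide to the step on the core of compound 2, and in this series the outcome of the change has to be read core by core. The result rests on a single pair per core, and the two cores differ in more than one place, so it does not show which structural difference goes with the reversal, nor why the step reverses.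

Still open, going by these compounds, is which part of the two cores sets the direction of the step, a question that needs compounds differing from compound 1 or compound 2 in one place only. Also open, on these data alone, is whether fluoro, an amine or a carboxylic acid at the same place would split between the two cores as chloro does.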